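Chlorine added to the aniline ring of a sulfonylamidoxime

The source may hold more compounds than are shown below. What is called first, only, known or untested is meant among the compounds shown, and "the series" means these compounds.

Measured compounds in a functional assay on TSGH 8302 cells (Homo sapiens) for cytotoxicity; on this read-out lower numbers stand for stronger inhibition and higher numbers for weaker inhibition:
compound 1, `Cc1ccc(S(=O)(=O)N/C(=N\O)Nc2ccc(Cl)cc2)cc1`, gives 46 ug/mL
compound 2, `O=[N+]([O-])c1ccc(Oc2c(Cl)cc(S(=O)(=O)N/C(=N\O)Nc3ccc(Cl)cc3)cc2Cl)cc1`, gives 7 ug/mL
compound 3, `O=[N+]([O-])c1ccc(Oc2c(Cl)cc(S(=O)(=O)N/C(=N\O)Nc3ccc(Cl)cc3)cc2Cl)c(Cl)c1`, gives 7 ug/mL

Compound 1 has the highest number of the three measured compounds. Compound 2 and compound 3 share a core that differs from the core of compound 1 in a way that is not broken down here; their two values, taken beside the value of compound 1, show a lower number for both. Between compound 2 and compound 3 the change is chloro in place of hydrogen on an aromatic carbon, and this gave no change at the digits printed from compound 2 to compound 3 (within the scatter).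

Compound 4, `Cc1ccc(S(=O)(=O)N/C(=N\O)Nc2ccc(Cl)c(Cl)c2)cc1`, is not yet measured. It differs from compound 1 by chloro in place of hydrogen on an aromatic carbon. Among the measured compounds shown here, this is the same kind of change as the one from compound 2 to compound 3, but not the same: in compound 4 the new chloro sits ortho to a chloro group and meta to a large group, whereas in compound 3 it sits ortho to a large group and meta to a nitro group.

For the measured compounds named here, with only one measured example of this kind of change, which gave no change within the scatter, compound 4 is expected to stay close to compound 1, with an estimated step of a 1.2-fold lower number from compound 1 to compound 4 (0.06 log units; within the scatter). Compound 4 is therefore estimated at 40 ug/mL in this assay, with a range from 15 ug/mL to 100 ug/mL.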

Compound 4, half-maximal inhibitory concentration: 67 ug/mL
Estimate against measurement, compound 4: 1.7-fold (0.22 log units) below, and the stated range covers the measured number.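

In this assay, chloro in place of hydrogen on an aromatic carbon of the core of compound 1, ortho to a chloro group and meta to a large group, gave a 1.5-fold higher number from compound 1 to compound 4 (0.16 log units; within the scatter). Set beside the earlier step, the change carries across the two cores without a detectable difference: the same change on two cores in this assay, no change at the digits printed (within the scatter) from compound 2 to compound 3 and a 1.5-fold higher number (0.16 log units; within the scatter) from compound 1 to compound 4, 1.5-fold (0.16 log units) apart, within the scatter of two such steps. Among the compounds shown here, this shows only that the change left the number within the scatter in both of these pairs; it does not establish a general rule for the series, since there are just two pairs, the new chloro sits at a different place in each, and neither step is large enough to reveal a shared effect of any size.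

The compounds shown leave open whether chloro would also leave the number within the scatter on other cores or at other aromatic carbons, and whether an amine, a carboxylic acid or a longer chain in place of the same hydrogen would give a step beyond the scatter. They also leave open which single parts of the difference between the core of compound 1 and the core of compound 2 account for the gap between their numbers, as those two compounds differ in more than one place.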